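Chloro added to the anilide of a methylated quinolone

The compounds below may be only part of what the source reports. "The series", "measured", "known", "first", "only" and "open" are said of these compounds alone.

The study follows a small series of anilides built on a shared core. Compound 1 `O=C(Nc1ccc(Cl)c(Cl)c1)c1c[nH]c2ccccc2c1=O` is the unmethylated member; in an assay on isolated protein for inhibition of Amine oxidase [flavin-containing] B (Homo sapiens), read by fluorescence and spectrophotometry, with a stated time of 30 min (a higher number here means a weaker inhibitor, a lower number a stronger inhibitor), compound 1 gives 11100 nM. Compound 2 `Cn1cc(C(=O)Nc2cccc(Cl)c2)c(=O)c2ccccc21` carries a methyl on the ring nitrogen and a single chloro on the anilide ring; in this assay compound 2 gives 29000 nM, the highest of the two numbers recorded, and its nearest neighbour is compound 1 at a lower number, a gap that is beyond the usual scatter.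

Compound 3 `Cn1cc(C(=O)Nc2ccc(Cl)c(Cl)c2)c(=O)c2ccccc21` has not yet been measured. It differs from compound 2 in one place: chloro in place of hydrogen on an aromatic carbon. For the measured compounds named here, no measured pair in this set isolates this exact change, so the direction and size of the step cannot be read from the data. The author expects a modest move toward a lower number, possibly no larger than the scatter, and estimates the step of a 2.1-fold lower number from compound 2 to compound 3 (0.32 log units; beyond the scatter) in this assay. Compound 3 is therefore expected to give about 14000 nM in this assay, within a range from 5000 nM to 40000 nM.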

Compound 3, half-maximal inhibitory concentration: 5300 nM
Estimate against measurement, compound 3: 2.6-fold (0.42 log units) above; the measured number falls inside the stated range.
By their numbers in this assay, from the lowest: compound 3; then compound 1; then compound 2.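

The added chloro sits on an aromatic carbon of the anilide ring, ortho to a chloro group and para to a large group, and in this assay it gives a 5.5-fold lower number from compound 2 to compound 3 (0.74 log units; beyond the scatter), which shows that this one position on the anilide ring moves the number by more than the scatter. Compound 3 also forms a second one-place pair: with the anilide unchanged, methyl in place of hydrogen on the aromatic nitrogen gives a 2.1-fold lower number from compound 1 to compound 3 (0.32 log units; beyond the scatter), so both single changes leading to compound 3 go toward a lower number. Nothing available explains either step.

The compounds shown leave open whether the chloro step would hold on the core of compound 1, where the ring nitrogen carries hydrogen, and whether a methoxy group, an amine or a carboxylic acid at the same aromatic carbon would move the number in the same direction. They also leave open whether a longer chain in place of the methyl on the ring nitrogen would take the number lower still or bring it back up.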